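A few compounds are considered here, and "the series" means these few. Any claim that something is new, unique, unknown or untested is made for them only; others in the source may bear on it.

Measured in a functional assay on PC-3 cells (Homo sapiens) for cytotoxicity; a higher number here means a weaker inhibitor, a lower number a stronger inhibitor:
- compound 1 `CS(=O)(=O)c1ccc2nc(NC(=O)CCCCCCC(=O)NO)sc2c1`: 5.69 ug/mL
- compound 2 `CS(=O)(=O)c1ccc2nc(NC(=O)CCCCC(=O)NO)sc2c1`: > 30 ug/mL, a limit
- compound 3 `O=C(CCCCC(=O)Nc1nc2ccc([N+](=O)[O-])cc2s1)NO`: > 30 ug/mL, a limit

Compound 1 is the only one of the three with a readable number. Compound 2 and compound 3 give no number, only (the limit of > 30 ug/mL in this assay, at which 2 of the 3 values shown sit).

Compound 4 `CCOc1ccc2nc(NC(=O)CCCCCCC(=O)NO)sc2c1` carries ethoxy in place of methylsulfonyl on an aromatic carbon, and the chain stays as it is: ethoxy in place of methylsulfonyl on an aromatic carbon.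

Two measured steps come into view. The chain change in an at least 5.2-fold higher number from compound 1 to compound 2 (0.72 log units; beyond the scatter) lies beyond the scatter, but the exchange in compound 4 leaves the chain untouched, so this step says little about its size. The closer parallel also replaces methylsulfonyl on an aromatic carbon, yet a step that the two limits leave unreadable from compound 2 to compound 3 gives no size at all. Nothing measured therefore sizes the exchange directly.

Compound 4 keeps the chain of compound 1, which gives 5.69 ug/mL, so no step beyond the scatter is expected in this assay, in either direction, although the uncertainty is wide. The expected change is a 1.1-fold higher number from compound 1 to compound 4 (0.02 log units; within the scatter). For compound 4 the estimated value is 6 ug/mL, with an expected range from 2 ug/mL to 20 ug/mL.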

Compound 4, half-maximal inhibitory concentration: 16.9 ug/mL
The estimate for compound 4 lay 2.8-fold (0.45 log units) below the measured number, and the stated range covers the measured number.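

In this assay, ethoxy in place of methylsulfonyl on this aromatic carbon, with the chain left as it is, gives a 3.0-fold higher number from compound 1 to compound 4 (0.47 log units; beyond the scatter), so the group at this place does alter the result even when the chain is held constant. The exchange also leaves a readable value, as compound 4 gives 16.9 ug/mL, so on this chain the loss of methylsulfonyl does not by itself take away a readable number. This is the first readable size for an exchange at this carbon, since the earlier one, nitro in place of methylsulfonyl, cannot be read, with compound 2 and compound 3 both standing at a limit rather than a number: the limit of > 30 ug/mL in this assay, at which 2 of the 4 values shown sit.

Within the data shown here, with only one readable exchange at this carbon, it stays open whether nitro, an amine or a carboxylic acid placed here on the chain of compound 1 would fall nearer to compound 1 or to compound 4. As far as these compounds go, it also stays open whether ethoxy would give a readable value on the shorter chain of compound 2, and how either group would behave on a longer chain than that of compound 1.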